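The source may hold more compounds than are shown below. What is called first, only, known or untested is meant among the compounds shown, and "the series" means these compounds.

Compound 1 `Clc1ccc(-n2nncc2-c2cccnc2)cc1`: 27 mg/kg
Compound 2 `Brc1ccc(-n2nncc2-c2cccnc2)cc1`: 40.7 mg/kg

Within the data shown here, in a functional assay on the whole organism with Mus musculus as the target (a lower number here means that less compound is needed, a higher number that more compound is needed for the effect), compound 2 gives the higher of the two numbers, with compound 1 as its only neighbour; the single measured step, a 1.5-fold higher number from compound 1 to compound 2 (0.18 log units; within the scatter), lies within the scatter. Compound 3 `Brc1ccc(-n2nncc2-c2ccccn2)cc1` differs from compound 2 by pyridin-2-yl in place of pyridin-3-yl on an aromatic carbon. Among the measured compounds shown here, no measured step involves this change, so no direction beyond the scatter is expected in this assay. Compound 3 is therefore estimated to give about 40 mg/kg, in a range from 15 mg/kg to 110 mg/kg. The expected step is a 1.0-fold lower number from compound 2 to compound 3 (0.01 log units; within the scatter).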

Compound 3, dose for half-maximal effect: 88.6 mg/kg
Estimate against measurement, compound 3: 2.2-fold (0.35 log units) below, within the range that was stated.
By their numbers in this assay, from the lowest: compounds 1 and 2 (each within the scatter of the next); then compound 3.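

The halogen exchange gave no step beyond the scatter, whereas this change on the aromatic carbon of the five-membered ring does, modestly, in this assay (a 2.2-fold higher number from compound 2 to compound 3 (0.34 log units; beyond the scatter)). Although pyridin-2-yl and pyridin-3-yl have the same atoms and the same counts, this position therefore distinguishes between them. Nothing available accounts for the difference.

From the compounds shown here alone, whether the change would read the same with chloro in place of bromo remains open. So does how pyridin-4-yl, a plain phenyl ring or an amine would fare at this position.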